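This account rests on a few compounds, and the source may have more. Where it says the series, first, only, none or still open, it means among the compounds named here.

Within the data shown here, compound 1 `Cc1cccc(CSc2cc(Cl)c(C)cc2S(=O)(=O)/N=C(\N)n2nccc2-c2ccccc2)c1` stands highest of the three numbers so far in an ADME assay on microsomes from liver (Homo sapiens) for metabolic stability, read by LC-MS, using NADPH, tested at 5 uM (on this read-out higher numbers stand for a longer-lived compound and lower numbers for a shorter-lived compound), giving 0.232 h. Its nearest neighbour, compound 2 `Cc1ccc(CSc2cc(Cl)c(C)cc2S(=O)(=O)/N=C(\N)n2nc(C)cc2-c2ccccc2)cc1`, gives 0.176 h, and compound 3 `Cc1cc(-c2ccccc2)n(/C(N)=N/S(=O)(=O)c2cc(C)c(Cl)cc2SCc2cccc(C(F)(F)F)c2)n1` gives 0.169 h; both gaps from compound 1 lie within the scatter, so the three compounds are not told apart on this read-out.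

Compound 4 `Cc1cc(S(=O)(=O)/N=C(\N)n2nccc2-c2ccccc2)c(SCc2ccccc2)cc1Cl` differs from compound 1 by hydrogen in place of methyl on an aromatic carbon. Among the measured compounds shown here, only one single-point step has been measured among the known compounds, a 1.0-fold lower number from compound 2 to compound 3 (0.02 log units; within the scatter), and it concerns the group on the saturated chain carbon bound to a sulfur rather than the change here; it lay within the scatter. For the measured compounds named here, no measured step touches the methyl that leaves in compound 4, so there is nothing to suggest a shift beyond the scatter, and the expectation is that the step of a 1.1-fold lower number from compound 1 to compound 4 (0.04 log units; within the scatter) stays within it. Compound 4 is therefore estimated at 0.21 h, within a range from 0.11 h to 0.4 h.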

Compound 4, half-life: 0.0772 h
The estimate for compound 4 lay 2.7-fold (0.43 log units) above the measured number; measured number below the stated range.
By their numbers in this assay, from the lowest: compound 4; then compounds 3, 2 and 1 (each within the scatter of the next).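

In this assay the change from 3-methylbenzyl to benzyl gives a 3.0-fold lower number from compound 1 to compound 4 (0.48 log units; beyond the scatter) and so passes beyond the scatter, whereas the replacement on this benzyl group in a 1.0-fold lower number from compound 2 to compound 3 (0.02 log units; within the scatter) stays within it. The ring carbon that loses its methyl is therefore a place where this read-out can respond to the removal of a single carbon, at least in the setting of compound 1. Nothing available explains why the half-life falls with this change.

The compounds shown leave open whether another group at this place, such as a methoxy, a chlorine or a hydroxyl, would give a number like that of compound 1 or one like that of compound 4. They also leave open whether removing this methyl would give a step of the same size on the core of compound 2.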